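The source may report more compounds than this note shows. Statements on the series, on what has been measured and on what is new or still open speak of the compounds shown alone.

In a functional assay on KB cells (Homo sapiens) for cytotoxicity (on this read-out lower numbers stand for an effect already at smaller amounts and higher numbers for an effect only at larger amounts of compound), compound 1 (`CCOc1cc(-c2ccccc2)nc2ccccc12`) gives 6.7 ug/mL, the higher of the two actual numbers. Compound 3 (`COc1ccc2nc(-c3ccccc3)cc(O)c2c1`) gives 0.08 ug/mL, a much lower number and a gap well beyond the scatter. Compound 2 (`Oc1cc(-c2ccccc2)nc2cc(F)ccc12`) reads < 0.1 ug/mL, which is a limit of the assay and not a number. Compound 4 (`CCCCOc1cc(-c2ccccc2)nc2ccccc12`) is still unmeasured and differs from compound 1 as follows: ethyl in place of hydrogen on a saturated chain carbon, two bonds along the chain from an oxygen on an aromatic ring, ethyl in place of hydrogen on a saturated chain carbon, so ethoxy to butoxy. Among the measured compounds shown here, no measured pair shows this kind of change. In this assay the expected 1.1-fold lower number from compound 1 to compound 4 (0.05 log units; within the scatter) is therefore no step beyond the scatter. Compound 4 is expected at 6 ug/mL, with an estimated range of 2 ug/mL to 20 ug/mL.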

Compound 4, half-maximal effective concentration: 3.8 ug/mL
Compound 4: the middle estimate sits 1.6-fold (0.20 log units) above what was measured; low and high end bracket the measured number.
By their numbers in this assay, from the lowest: compound 3; then compounds 4 and 1 (each within the scatter of the next).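

Among the compounds shown here, the ethyl on a saturated chain carbon, two bonds along the chain from an oxygen on an aromatic ring, gives the first reading at this place: in this assay there is a 1.8-fold lower number from compound 1 to compound 4 (0.25 log units; within the scatter) for ethoxy to butoxy. This place therefore takes the added ethyl with no step beyond the scatter. Nothing shown gives a cause for this result.

Going by these compounds, whether an amine or a carboxylic acid on this chain, or a chain longer than butoxy, would behave alike stays open. Compound 2 and compound 3 differ from compound 1 in more than one place, so ethoxy against hydroxyl on the shared core stays unread.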